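Shifting the Anilino Substituent from Fluorine to Methyl

A few compounds are considered here, and "the series" means these few. Any claim that something is new, unique, unknown or untested is made for them only; others in the source may bear on it.

Among the compounds with values here, compound 2 `COC(=O)C1=C(Nc2ccc(F)cc2)O/C(=C\c2c[nH]c3ncccc23)C1=O` gives 52% in an ADME assay on microsomes from liver (Homo sapiens) for metabolic stability, read by LC-MS, using NADPH, with a stated time of 30 min, tested at 1 uM (on this read-out lower numbers stand for a less stable compound and higher numbers for a more stable compound), the higher of the two numbers measured so far. Within the data shown here, its nearest neighbour, compound 1 `COC(=O)C1=C(Nc2ccccc2F)O/C(=C\c2c[nH]c3ncccc23)C1=O`, gives 30% in this assay, and the only step measured, a number 22 percentage points higher from compound 1 to compound 2 (beyond the scatter), lies beyond the scatter. Compound 3 `COC(=O)C1=C(Nc2ccccc2C)O/C(=C\c2c[nH]c3ncccc23)C1=O` differs from compound 2 by 2-methylphenyl in place of 4-fluorophenyl on an amine nitrogen. That measured step is the only one that bears on this change: it shows that moving a fluorine from the 2-position to the 4-position of the phenyl ring raised the number by a modest amount, and compound 3 returns to a 2-substituted phenyl, now carrying a methyl. Among the measured compounds shown here, no measured compound carries a methyl on this ring, so the comparison is indirect. Compound 3 is therefore expected to fall back toward compound 1, an estimated step of a number 17 percentage points lower from compound 2 to compound 3 (beyond the scatter). The estimate for compound 3 is 35%, with a range from 15% to 55%.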

Compound 3, percent of the compound remaining: 53%
For compound 3 the middle estimate is 18 percentage points below the measured one; the measured number falls inside the stated range.
By their numbers in this assay, from the lowest: compound 1; then compounds 2 and 3 (each within the scatter of the next).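

With the fluoro exchanged for methyl, the number rises (a number 23 percentage points higher from compound 1 to compound 3 (beyond the scatter)), so the group on the ring matters as well as where it stands. In this assay, the 2-methylphenyl and 4-fluorophenyl groups on the amine nitrogen cannot be told apart (a number 1 percentage points higher from compound 2 to compound 3 (within the scatter)), which leaves the 2-fluorophenyl group of compound 1 as the only one of the three to stand apart. Nothing given here explains these numbers. The compounds shown leave open how a 4-methylphenyl group would read on this amine nitrogen, and so whether moving the methyl would matter as moving the fluorine did. They also leave open whether a chloro or methoxy group on the ring would follow the methyl or the fluoro.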